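Fluoropyridine swap on the compound 2 scaffold

A few compounds are considered here, and "the series" means these few. Any claim that something is new, unique, unknown or untested is made for them only; others in the source may bear on it.

Among the measured compounds shown here, in a functional assay on A549 cells (Homo sapiens) for antiproliferative activity, read by sulforhodamine B assay, with a stated time of 48 h (on this read-out higher numbers stand for weaker inhibition and lower numbers for stronger inhibition), compound 2 `O=C(/C=C/c1ccccc1-c1ccc(F)cc1)c1cccc(O)c1` gives 6900 nM, the only actual number so far. Compound 1 `COc1ccc(C(=O)/C=C/c2ccccc2-c2ccc(F)nc2)cc1`, which also carries 6-fluoropyridin-3-yl, reads > 50000 nM, and this is a limit of the assay, not a number. Compound 3 `O=C(/C=C/c1ccccc1-c1ccc(F)nc1)c1cccc(O)c1` departs from compound 2 at one place, with 6-fluoropyridin-3-yl in place of 4-fluorophenyl on an aromatic carbon, ortho to a large group: 6-fluoropyridin-3-yl in place of 4-fluorophenyl on an aromatic carbon. For the measured compounds named here, no measured step covers this change, so the expectation rests on thin ground, namely compound 2 at 6900 nM as the starting point and a cautious lean towards weaker inhibition. In this assay the expected step is a 2.2-fold higher number from compound 2 to compound 3 (0.34 log units; beyond the scatter), a modest weakening little beyond the usual scatter. For compound 3 the estimate is 15000 nM, with an expected range from 4000 nM to 45000 nM.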

Compound 3, half-maximal inhibitory concentration: 6900 nM
Compound 3: the middle estimate sits 2.2-fold (0.34 log units) above what was measured; the measured number falls inside the stated range.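

In this assay, 6-fluoropyridin-3-yl in place of 4-fluorophenyl, on an aromatic carbon ortho to a large group, costs nothing measurable: the pair shows no change at the digits printed from compound 2 to compound 3 (within the scatter). With 6-fluoropyridin-3-yl held constant, the group on the carbonyl carbon does separate the compounds, as 3-hydroxyphenyl in place of 4-methoxyphenyl gives an at least 7.2-fold lower number from compound 1 to compound 3 (0.86 log units; beyond the scatter). The reading for compound 1 is a limit and not a number, so this step has only a lower bound: the limit of > 50000 nM in this assay, at which 1 of the 3 values shown sits.

Whether that step follows the hydroxy group or its place on the ring stays open, since 4-hydroxyphenyl and 3-methoxyphenyl lie outside the compounds shown. Also open, from the compounds shown here alone, is how an amine in place of the fluorine of 6-fluoropyridin-3-yl would read.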